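This account rests on a few compounds, and the source may have more. Where it says the series, first, only, none or still open, it means among the compounds named here.

Measured so far:
- compound 1 `CCC(=O)N(c1ccc(C)cc1)C1CCCC1N(C)C`: 10 mg/kg; 10 mg/kg (2 entries)
- compound 2 `CCC(=O)N(c1ccc([N+](=O)[O-])cc1)C1CCCC1N(C)C`: 20 mg/kg

Among the measured compounds shown here, in a functional assay on the whole organism for positive allosteric modulation, with Mus musculus as the target (on this read-out higher numbers stand for an effect only at larger amounts of compound and lower numbers for an effect already at smaller amounts), compound 2 gives 20 mg/kg, and this is the only single reading. The other compound was recorded twice, with compound 1 at 10 mg/kg; 10 mg/kg (2 entries). These two compounds lie within the usual scatter of each other, so no order can be drawn between them.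

Compound 3 `CCC(=O)N(c1ccc(C(=O)OC)cc1)C1CCCC1N(C)C` keeps the core of compound 2 and has methoxycarbonyl in place of nitro on an aromatic carbon, para to a large group: methoxycarbonyl in place of nitro on an aromatic carbon. For the measured compounds named here, no measured pair isolates this exchange, so the basis for an expectation is thin. It rests on compound 1 at 10 mg/kg; 10 mg/kg (2 entries) and compound 2 at 20 mg/kg, which carry different groups at this place and still do not separate beyond the scatter.

In this assay no shift beyond the usual scatter is expected, and the estimated move is a 1.3-fold lower number from compound 2 to compound 3 (0.12 log units; within the scatter). For compound 3 the expected value is 15 mg/kg, with an estimated range from 6 mg/kg to 40 mg/kg.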

Compound 3, dose for half-maximal effect: > 50 mg/kg
Compound 3 was reported as a limit (the forecaster's own chance of this, stated with the estimate: 10%); middle value at least 3.3-fold (0.52 log units) from the limit.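

In this assay, methoxycarbonyl in place of nitro on this aromatic carbon brings an at least 2.5-fold higher number from compound 2 to compound 3 (0.39 log units; beyond the scatter). Among the compounds shown here, this is the first separation beyond the scatter; compound 1 and compound 2 lie within the scatter of each other and gave no sign that the group at this place could matter. Compound 3 is reported as a limit and not as a number, so the step has only a lower bound and its full size cannot be read: the limit of > 50 mg/kg in this assay, at which 1 of the 3 values shown sits.

Nitro and methoxycarbonyl carry the same counts of hydrogen-bond donors and acceptors, so those counts alone do not separate the two groups on this read-out, and the compounds shown do not settle what does. Still open, as far as these compounds go, is whether the higher number belongs to methoxycarbonyl alone or extends to related groups on this aromatic carbon, such as a carboxylic acid or a primary amide, and whether an amine or a longer alkyl chain there would stay within the scatter of compound 1 and compound 2.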